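Closing a series of amides at the vitamin D receptor

The source may report more compounds than this note shows. Statements on the series, on what has been measured and on what is new or still open speak of the compounds shown alone.

Three compounds have been examined in an assay on isolated protein for inhibition of vitamin D3 receptor (Homo sapiens), read by fluorescence polarization (on this read-out lower numbers stand for stronger inhibition and higher numbers for weaker inhibition), and a fourth awaits measurement. Compound 1 `CN(Cc1cccc(F)c1)C(=O)CCCNC(=O)c1ccc(S(C)(=O)=O)c([N+](=O)[O-])c1` carries a (3-fluorobenzyl)(methyl)amino group on a carbonyl carbon whose other neighbour is a saturated chain carbon. In this assay compound 1 gives > 60000 nM, which is a limit of the assay and not a number. Compound 2 `CN(Cc1cccc(F)c1)C(=O)CN(C)C(=O)c1ccc(S(C)(=O)=O)c([N+](=O)[O-])c1` shares its outer groups with compound 1, but the difference between the two cores is not broken down here. In this assay compound 2 gives > 60000 nM, again a limit rather than a number. Compound 3 `CC1CCN(C(=O)CCCNC(=O)c2ccc(S(C)(=O)=O)c([N+](=O)[O-])c2)CC1` arises from compound 1 by the change (4-methylpiperidin-1-yl in place of (3-fluorobenzyl)(methyl)amino on a carbonyl carbon). In this assay compound 3 gives > 60000 nM, once more a limit. The step that the two limits leave unreadable from compound 1 to compound 3 therefore cannot be read, because of the limit of > 60000 nM in this assay, at which 3 of the 3 values shown sit.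

The unmeasured compound 4 `CC1CCN(C(=O)CN(C)C(=O)c2ccc(S(C)(=O)=O)c([N+](=O)[O-])c2)CC1` arises from compound 2 by the change (4-methylpiperidin-1-yl in place of (3-fluorobenzyl)(methyl)amino on a carbonyl carbon), the same change that led from compound 1 to compound 3. The expected step that the limit leaves unreadable from compound 2 to compound 4 is estimated to be unreadable in the same way, since compound 2 sits at the limit > 60000 nM and the same change on compound 1 gave compound 3 at the limit > 60000 nM. For compound 4 an estimate of 90000 nM is given, with a range from 30000 nM to 400000 nM, and the likeliest outcome is that this assay reports only a limit.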

Compound 4, half-maximal inhibitory concentration: > 60000 nM
Compound 4: no number, only a limit (the forecaster's own chance of this, stated with the estimate: 90%); the middle value is on the limit's open side.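

Compound 4, like compound 2, gives no number in this assay, so the step between compound 2 and compound 4 cannot be read, because both values are limits of the assay: the limit of > 60000 nM in this assay, at which 4 of the 4 values shown sit. The compounds shown leave open how strongly any of them inhibits the receptor, and whether placing 4-methylpiperidin-1-yl in place of (3-fluorobenzyl)(methyl)amino changes that inhibition at all.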